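Swapping fluoro for trifluoromethyl: solubility of compound 3

The compounds below may be only part of what the source reports. "The series", "measured", "known", "first", "only" and "open" are said of these compounds alone.

Measured so far:
- compound 1 `COC(=O)N[C@H](C(=O)N1CCC[C@H]1C(=O)Nc1ccc([C@H]2CC[C@H](c3ccc(NC(=O)[C@@H]4CCCN4C(=O)[C@@H](NC(=O)OC)C(C)C)cc3)N2c2ccc(C(F)(F)F)cc2)cc1)C(C)C`: 3200 nM
- compound 2 `COC(=O)N[C@H](C(=O)N1CCC[C@H]1C(=O)Nc1ccc([C@@H]2CC[C@@H](c3ccc(NC(=O)[C@@H]4CCCN4C(=O)[C@@H](NC(=O)OC)C(C)C)cc3)N2c2ccc(F)cc2)cc1)C(C)C`: 4100 nM

Of the compounds shown here, two have been measured in a physicochemical assay for solubility, in phosphate buffer, measured as kinetic solubility, at pH 7.2; a higher number here means a more soluble compound, a lower number a less soluble compound. Compound 1 gives 3200 nM. Compound 2 gives 4100 nM, the higher of the two numbers, but its gap to compound 1 is within the scatter, so the two cannot be told apart by this assay.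

Compound 3 `COC(=O)N[C@H](C(=O)N1CCC[C@H]1C(=O)Nc1ccc([C@@H]2CC[C@@H](c3ccc(NC(=O)[C@@H]4CCCN4C(=O)[C@@H](NC(=O)OC)C(C)C)cc3)N2c2ccc(C(F)(F)F)cc2)cc1)C(C)C` has not yet been measured. It differs from compound 2 in one place: trifluoromethyl in place of fluoro on an aromatic carbon. Within the data shown here, no measured pair in this set shows this exact exchange, so there is no direct step to lean on. What the two measured values do show is that the spread among these compounds is small.

The expectation for compound 3 is therefore a step of a 1.4-fold lower number from compound 2 to compound 3 (0.14 log units; within the scatter), downward if anything but not clearly beyond the scatter. Compound 3 is estimated at 3000 nM, with a range from 1500 nM to 6000 nM.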

Compound 3, solubility: 3400 nM
Compound 3: middle estimate off by 1.1-fold (0.05 log units), on the low side; the measured number falls inside the stated range.
By their numbers in this assay, from the lowest: compounds 1, 3 and 2 (each within the scatter of the next).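

In this assay, trifluoromethyl in place of fluoro on an aromatic carbon, para to a large group, gives a 1.2-fold lower number from compound 2 to compound 3 (0.08 log units; within the scatter), so at this position the change from 4-fluorophenyl to 4-(trifluoromethyl)phenyl cannot be told from no change at all. Compounds 1 and 2 differ in two places, and compound 3 now separates those two differences, so each can be read alone; the second is a change of configuration at two saturated ring carbons, which gives a 1.1-fold higher number from compound 1 to compound 3 (0.03 log units; within the scatter) and is likewise not resolved by this measurement. That second step is a clean test of configuration, because nothing else changes in the structure: the fact that compounds 1 and 3 differ only in the configuration as drawn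

The compounds shown leave open whether a group of a different kind at this position, such as an amine or a carboxylic acid, would give a step beyond the scatter. They also leave open whether the two configurations would still be indistinguishable with fluoro at this position, as the configuration step here is read with trifluoromethyl only.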